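This account rests on a few compounds, and the source may have more. Where it says the series, first, only, none or still open, it means among the compounds named here.

In a functional assay on SW-620 cells (Homo sapiens) for inhibition, read by MTT assay, with a stated time of 4 days (a higher number here means a weaker inhibitor, a lower number a stronger inhibitor), the three measured compounds all sit at a limit rather than at a number. Compound 1 `O=C1NCCN1C(c1ccccc1)(c1ccccc1)c1ccccc1` gives >= 100000 nM, a limit of the assay. Compound 2 `COc1cc(NC(C)CCCNC(=O)NNC(=O)N(CCO)CCO)c2ncccc2c1` gives > 100000 nM, likewise a limit. Compound 3 `COc1cc(NC(C)CCCNC(=O)NNC(=O)NCCCC(C)Nc2cc(OC)cc3cccnc23)c2ncccc2c1` gives > 100000 nM, again a limit. Compound 2 therefore stands where every other value stands, at the edge the assay can report, with nothing to separate it from the rest (the limit of > 100000 nM in this assay, at which 2 of the 3 values shown sit; (the limit of >= 100000 nM in this assay, at which 1 of the 3 values shown sits)). Compound 4 `COc1cc(NC(C)CCCNC(=O)NNC(=O)NCCCO)c2ncccc2c1` differs from compound 2 in one place: (3-hydroxypropyl)amino in place of bis(2-hydroxyethyl)amino on a carbonyl carbon. Within the data shown here, no measured pair shows what this change does. Compound 4 is expected to remain at the limit, so the step in this assay is estimated at a number no higher from compound 2 to compound 4 (the limit leaves the size open), none beyond the scatter. Compound 4 is thus estimated at 100000 nM, within 30000 nM to 300000 nM.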

Compound 4, half-maximal inhibitory concentration: > 100000 nM
Compound 4: a limit, no number; the forecaster's own chance of this, stated with the estimate: 85%; the middle value lies on the limit itself.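

Among these compounds, compound 2 and compound 4 both sit at a limit in this assay, so no step between them can be read. The compounds shown leave open what (3-hydroxypropyl)amino in place of bis(2-hydroxyethyl)amino does to inhibition.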